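The source may report more compounds than this note shows. Statements on the series, on what has been measured and on what is new or still open speak of the compounds shown alone.

Measured so far in a functional assay on A549 cells (Homo sapiens) for inhibition, read by CCK-8 assay, with a stated time of 72 h, tested at 1 uM; on this read-out higher numbers stand for more inhibition of growth at the one concentration tested and lower numbers for less inhibition of growth:
compound 1 `Cc1cccc(NC(=O)C2(C(=O)Nc3ccc(Nc4ncc5cc(C(=O)N(C)C)n(C6CCCC6)c5n4)cc3)CC2)c1` gives 35.2%
compound 2 `CN(C)C(=O)c1cc2cnc(Nc3ccc(NC(=O)C4(C(=O)Nc5ccc(Cl)cc5)CC4)cc3)nc2n1C1CCCC1` gives 24.7%

Compound 2, at 24.7%, is the lower of the two numbers. Compound 3 `CN(C)C(=O)c1cc2cnc(Nc3ccc(NC(=O)C4(C(=O)Nc5cccc(F)c5)CC4)cc3)nc2n1C1CCCC1` carries 3-fluorophenyl in place of 4-chlorophenyl on an amide-type nitrogen. Going by the values given here, only one measured step bears on this place, a number 10.5 percentage points lower from compound 1 to compound 2 (beyond the scatter), where 4-chlorophenyl replaced 3-methylphenyl. With 4-chlorophenyl leaving again, a rise smaller than that step is expected in this assay, and it may stay within the scatter. The expected change is a number 5.3 percentage points higher from compound 2 to compound 3 (within the scatter). For compound 3 the estimated value is 30%, with an expected range of 18% to 43%.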

Compound 3, percent growth inhibition at one concentration: 33.2%
The estimate for compound 3 lay 3.2 percentage points below the measured number, within the range that was stated.
By their numbers in this assay, from the lowest: compounds 2, 3 and 1 (each within the scatter of the next, the first and the last beyond it).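

In this assay the change from 4-chlorophenyl to 3-fluorophenyl on the amide-type nitrogen reads a number 8.5 percentage points higher from compound 2 to compound 3 (within the scatter) and fluoro in place of methyl on an aromatic carbon reads a number 2 percentage points lower from compound 1 to compound 3 (within the scatter). The 3-fluorophenyl and 3-methylphenyl amides therefore cannot be told apart here, and only compound 1 and compound 2 are separated beyond the scatter. No measurement at hand explains these numbers. Going by these compounds, whether a phenyl ring bearing an amine or a carboxylic acid on this nitrogen would leave the scatter remains open. So does the result of 3-chlorophenyl, which would separate the chlorine from its ring position.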